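Vero cytotoxicity: from trifluoromethylphenyl to chloro-fluorophenyl

This account rests on a few compounds, and the source may have more. Where it says the series, first, only, none or still open, it means among the compounds named here.

Three members of the series have been examined in an ADME assay on Vero cells (Chlorocebus sabaeus) for cytotoxicity, read by MTT assay, with a stated time of 72 h (a lower number here means that less compound is tolerated, a higher number that more compound is tolerated), so far. Compound 1 `C[C@]1(CN2CCc3nc(-c4ccc(F)cc4)nnc3C2)Cn2cc([N+](=O)[O-])nc2O1` gives "not determined" (no result reported) in this assay, and compound 2 `C[C@]1(CN2CCn3cc(-c4ccc(F)cc4)nc3C2)Cn2cc([N+](=O)[O-])nc2O1` likewise gives "not determined" (no result reported), so neither offers a number to compare against. Among the compounds with values here, compound 3 `C[C@]1(CN2CCc3nc(-c4ccc(C(F)(F)F)cc4)ccc3C2)Cn2cc([N+](=O)[O-])nc2O1` reaches only the limit of this assay, reported as > 32 ug/mL, and so its place on the scale is known only as a bound; it is the single entry with any reading, and that reading is the limit of > 32 ug/mL in this assay, at which 1 of the 3 values shown sits. Within the data shown here, no step between two measured compounds can be drawn from these entries.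

Compound 4 `C[C@]1(CN2CCc3nc(-c4cc(Cl)ccc4F)ccc3C2)Cn2cc([N+](=O)[O-])nc2O1` is the next candidate for this assay. It differs from compound 3 by 5-chloro-2-fluorophenyl in place of 4-(trifluoromethyl)phenyl on an aromatic carbon.

With compound 3 standing at the limit, the expected step that the limit leaves unreadable from compound 3 to compound 4 is none beyond the scatter, and the most likely outcome is another limit. The estimate for compound 4 in this assay is 40 ug/mL, with a range from 16 ug/mL to 100 ug/mL expected.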

Compound 4, half-maximal cytotoxic concentration: > 32 ug/mL
Compound 4: only a limit was reported; the forecaster's own chance of this, stated with the estimate: 70%; the middle value lies beyond the limit too.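

Within the data shown here, compound 3 and compound 4 both stand only at a limit in this assay, so no step between them can be read: the limit of > 32 ug/mL in this assay, at which 2 of the 4 values shown sit.

The compounds shown leave open where either compound lies on the scale, and whether 5-chloro-2-fluorophenyl and 4-(trifluoromethyl)phenyl differ in this read-out at all.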